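Truncating the sulfur side chain: working notes toward compound 4

The compounds below may be only part of what the source reports. "The series", "measured", "known", "first", "only" and "open" are said of these compounds alone.

Measured compounds in a functional assay on HT cells (Homo sapiens) for antiproliferative activity, read by fluorescence, with a stated time of 72 h; on this read-out lower numbers stand for stronger inhibition of growth and higher numbers for weaker inhibition of growth:
compound 1 `CC(C)c1n[nH]c2c(NCc3ccc(-c4ccccn4)cc3)nc(SCC(O)CO)nc12` gives 21 nM
compound 2 `CC(C)c1n[nH]c2c(NCc3ccc(-c4ccccn4)cc3)nc(SCC3CNC(=O)O3)nc12` gives 80 nM
compound 3 `CC(O)CSc1nc(NCc2ccc(-c3ccccn3)cc2)c2[nH]nc(C(C)C)c2n1` gives 62 nM

Compound 1 stands lowest of the three numbers: a 3.0-fold higher number from compound 1 to compound 3 (0.47 log units; beyond the scatter) and a 3.8-fold higher number from compound 1 to compound 2 (0.58 log units; beyond the scatter), both beyond the scatter. Compound 4 `CC(C)c1n[nH]c2c(NCc3ccc(-c4ccccn4)cc3)nc(S)nc12` differs from compound 1 in a single place: hydrogen in place of 2,3-dihydroxypropyl on a sulfur, or, cut one bond further out, (2,3-dihydroxypropyl)sulfanyl to sulfanyl. Among the compounds with values here, two measured steps bear on this. Removing one hydroxy from the chain, from compound 1 to compound 3, already raised the number modestly, and replacing the 1,2-dihydroxyethyl end, from compound 1 to compound 2, did likewise. Removing the whole 2,3-dihydroxypropyl group is a larger change than either, so a step upward at least as large as those is expected, a 9.5-fold higher number from compound 1 to compound 4 (0.98 log units; beyond the scatter). Compound 4 is therefore estimated at 200 nM, within 50 nM to 1000 nM.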

Compound 4, concentration for 50% growth inhibition: 2760 nM
The estimate for compound 4 lay 14-fold (1.14 log units) below the measured number; measured number above the stated range.
By their numbers in this assay, from the lowest: compound 1; then compounds 3 and 2 (each within the scatter of the next); then compound 4.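

Hydrogen on the sulfur costs far more than any change among the side chains so far: a 130-fold higher number from compound 1 to compound 4 (2.12 log units; beyond the scatter) and a 45-fold higher number from compound 3 to compound 4 (1.65 log units; beyond the scatter) and a 35-fold higher number from compound 2 to compound 4 (1.54 log units; beyond the scatter) all exceed the modest steps among compounds 1, 2 and 3. Within these four compounds, having any of the three side chains on the sulfur therefore matters much more than which one it is. Nothing available explains the size of these steps.

On these data alone, it remains open whether a simple methyl group on the sulfur would retain the numbers of the side-chain compounds. Also open, as far as these compounds go, is how a terminal amine, a carboxylic acid or a longer chain would compare with 2,3-dihydroxypropyl.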